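The source may report more compounds than this note shows. Statements on the series, on what has been measured and on what is new or still open speak of the compounds shown alone.

The measured compounds in a functional assay on A-431 cells (Homo sapiens) for cytotoxicity, read by MTT assay, with a stated time of 72 h (a lower number here means a stronger inhibitor, a higher number a weaker inhibitor), are two: compound 1 `N/C(=N\NC(=S)N1CCCCC1)c1ccccn1` gives 6900 nM, and compound 2 `Cc1cccc(/C(N)=N/NC(=S)N2CCOCC2)n1` gives 4300 nM.

Compound 2 sits at the low end of these two numbers, yet its gap to compound 1 falls within the scatter, so the two count as alike in this assay. Compound 3 `Cc1cccc(/C(N)=N/NC(=S)N2CCCCC2)n1` differs from compound 2 in one place: piperidin-1-yl in place of morpholin-4-yl on a thiocarbonyl carbon. Within the data shown here, no measured pair shows this exchange on its own, so no size can be read off for it. Compound 1 also carries piperidin-1-yl on its thiocarbonyl carbon, and with 6900 nM it stands close to compound 2, which speaks against a large move in either direction. The step is therefore expected to stay small, a 1.2-fold higher number from compound 2 to compound 3 (0.07 log units; within the scatter), without a clear direction beyond the scatter. Compound 3 is estimated to give 5000 nM in this assay, with a likely range from 2000 nM to 14000 nM.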

Compound 3, half-maximal inhibitory concentration: 12400 nM
The estimate for compound 3 lay 2.5-fold (0.39 log units) below the measured number; measured number inside the range.
By their numbers in this assay, from the lowest: compounds 2, 1 and 3 (each within the scatter of the next, the first and the last beyond it).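

In this assay, among these compounds, this is the first sign that the group on the thiocarbonyl carbon can shift the number beyond the scatter: piperidin-1-yl in place of morpholin-4-yl gives a 2.9-fold higher number from compound 2 to compound 3 (0.46 log units; beyond the scatter) on an otherwise unchanged structure. Methyl in place of hydrogen on an aromatic carbon, with piperidin-1-yl kept, gives a 1.8-fold higher number from compound 1 to compound 3 (0.25 log units; within the scatter) and so cannot be told apart from no change. Nothing available explains the step at the thiocarbonyl carbon.

The compounds shown leave open whether morpholin-4-yl and piperidin-1-yl would differ in the same way on the core without the methyl. They also leave open how a piperazin-1-yl or a dimethylamino group on the thiocarbonyl carbon would read in this assay against these two rings.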